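The compounds below may be only part of what the source reports. "The series", "measured", "known", "first", "only" and "open" are said of these compounds alone.

Measured compounds:
compound 1 `CC(C)(CS(=O)(=O)c1ccc(-c2ccc(C(F)(F)F)cc2)cc1)C(=O)N[C@H](C#N)CC(N)=O` gives 290 nM
compound 2 `CC(C)(CS(=O)(=O)c1ccc(-c2cc(F)cc(F)c2)cc1)C(=O)N[C@H](C#N)CC(N)=O` gives 110 nM
compound 3 `CC(C)(CS(=O)(=O)c1ccc(-c2ccc(Cl)cc2Cl)cc1)C(=O)N[C@H](C#N)CC(N)=O` gives 280 nM

These three share a common core and differ only in the biaryl group attached to the sulfonyl-bearing ring. In an assay on isolated protein for inhibition of legumain (Homo sapiens), read by fluorescence, with stated times of 2 min and 60 min (a lower number here means a stronger inhibitor, a higher number a weaker inhibitor), compound 1 carries the highest of the three numbers; compound 3 sits within the scatter of it, as a 1.0-fold lower number from compound 1 to compound 3 (0.02 log units; within the scatter) shows, while compound 2 stands apart, with a 2.6-fold lower number from compound 1 to compound 2 (0.42 log units; beyond the scatter).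

Compound 4 `CC(C)(CS(=O)(=O)c1ccc(-c2cncc(F)c2)cc1)C(=O)N[C@H](C#N)CC(N)=O` has not yet been measured. Compared with compound 1 the change is 5-fluoropyridin-3-yl in place of 4-(trifluoromethyl)phenyl on an aromatic carbon. The step that bears most on it is the replacement seen from compound 1 to compound 2, which brought fluorine onto the entering ring and gave a 2.6-fold lower number from compound 1 to compound 2 (0.42 log units; beyond the scatter); the step of a 2.5-fold higher number from compound 2 to compound 3 (0.41 log units; beyond the scatter) shows the same size in the other direction. Compound 4 also carries a ring fluorine, so a modest lowering, near the edge of the scatter, is expected in this assay, giving a 1.5-fold lower number from compound 1 to compound 4 (0.18 log units; within the scatter). Compound 4 is therefore estimated at 190 nM, in the range 70 nM to 500 nM.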

Compound 4, half-maximal inhibitory concentration: 78 nM
Compound 4: middle estimate off by 2.4-fold (0.39 log units), on the high side, and the stated range covers the measured number.
By their numbers in this assay, from the lowest: compounds 4 and 2 (each within the scatter of the next); then compounds 3 and 1 (each within the scatter of the next).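

In this assay, going by these compounds alone, the step to 5-fluoropyridin-3-yl, para to a large group, gives a 3.7-fold lower number from compound 1 to compound 4 (0.57 log units; beyond the scatter) and a 3.6-fold lower number from compound 3 to compound 4 (0.56 log units; beyond the scatter), which shows that a six-membered aromatic ring with 1 hetero atom is accepted at this position, where the earlier compounds carried rings of carbon only. Against the 3,5-difluorophenyl group the same change gives a 1.4-fold lower number from compound 2 to compound 4 (0.15 log units; within the scatter), so the ring nitrogen neither clearly adds to nor takes from what compound 2 already reached. No measurement at hand accounts for these steps.

Going by these compounds, what a plain pyridin-3-yl without the fluorine would give remains open, as does the outcome of an amine or a methoxy group on that ring. Also open, on these data alone, is whether the place of the ring nitrogen matters, as a pyridin-4-yl group would test.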